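Aryl swap on the ring nitrogen of the shared core

This account rests on a few compounds, and the source may have more. Where it says the series, first, only, none or still open, it means among the compounds named here.

Working notes on the series. Two compounds carry numbers in a functional assay on MCF7 cells (Homo sapiens) for cytotoxicity, read by MTT assay, with a stated time of 72 h; on this read-out higher numbers stand for weaker inhibition and lower numbers for stronger inhibition. Compound 1 `Cc1cc(=O)n(-c2ccc(Br)cc2F)nc1C(=O)Nc1ccc(Oc2ncnc3ccsc23)c(F)c1` gives 1550 nM. Compound 2 `Cc1cc(=O)n(-c2ccccc2C(F)(F)F)nc1C(=O)Nc1ccc(Oc2ncnc3sccc23)c(F)c1` gives 13800 nM, the higher of the two numbers, and its gap to compound 1 lies beyond the scatter. Within the data shown here, the two measured compounds differ in more than one place, so no single step between them is available. Compound 3 `Cc1cc(=O)n(-c2ccc(Br)cc2F)nc1C(=O)Nc1ccc(Oc2ncnc3sccc23)c(F)c1` is not yet measured. It differs from compound 2 in one place: 4-bromo-2-fluorophenyl in place of 2-(trifluoromethyl)phenyl on an aromatic nitrogen. A step toward lower numbers is expected for compound 3 because compound 1, which carries the same group on the aromatic nitrogen, gives 1550 nM. The expected step from compound 2 to compound 3 in this assay is a 5.5-fold lower number from compound 2 to compound 3 (0.74 log units; beyond the scatter). For compound 3 the estimate in this assay is 2500 nM, with a range from 800 nM to 8000 nM.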

Compound 3, half-maximal inhibitory concentration: 13300 nM
Estimate against measurement, compound 3: 5.3-fold (0.73 log units) below, outside the stated range (above it).
By their numbers in this assay, from the lowest: compound 1; then compounds 3 and 2 (each within the scatter of the next).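

On the aromatic nitrogen, with the group on the oxygen held as in compound 2, 4-bromo-2-fluorophenyl in place of 2-(trifluoromethyl)phenyl gives a 1.0-fold lower number from compound 2 to compound 3 (0.02 log units; within the scatter) in this assay, so this aryl change does not separate the two compounds in this setting. The other single-place comparison keeps 4-bromo-2-fluorophenyl fixed and exchanges only the group on the oxygen on an aromatic ring, giving an 8.6-fold higher number from compound 1 to compound 3 (0.93 log units; beyond the scatter), so a step beyond the scatter is seen at that place and not at the aromatic nitrogen. No measurement at hand accounts for either step. From the compounds shown here alone, it remains open whether the aryl change would also leave the number in the same range with the oxygen group of compound 1. Also open, going by these compounds, is how an aryl group carrying an amine or a carboxylic acid would read on the aromatic nitrogen.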